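The compounds below may be only part of what the source reports. "The series", "measured", "known", "first", "only" and "open" are said of these compounds alone.

Measured compounds:
compound 1, `CC#C[C@@H](CC(=O)O)c1ccc(OC[C@H]2COc3ccc(F)cc3O2)cc1`, gives 210 nM in a functional assay on HEK293 cells for agonist activity at Free fatty acid receptor 1 (Homo sapiens), read by fluorescence and calcium flux, with a stated time of 10 min; on this read-out higher numbers stand for an effect only at larger amounts of compound and lower numbers for an effect already at smaller amounts.
compound 2, `CC#C[C@@H](CC(=O)O)c1ccc(OC[C@H]2COc3ccc(Br)cc3O2)cc1`, gives 210 nM.
compound 3, `CC#C[C@@H](CC(=O)O)c1ccc(OC[C@H]2COc3ccc(OC)cc3O2)cc1`, gives 130 nM.

Compound 3 has the lowest of the three numbers, yet it is not set apart: the step of a 1.6-fold lower number from compound 1 to compound 3 (0.21 log units; within the scatter) and the step of a 1.6-fold lower number from compound 2 to compound 3 (0.21 log units; within the scatter) both stay within the scatter, as does no change at the digits printed from compound 1 to compound 2 (within the scatter). The three compounds therefore count as one group, and no substituent at that place has yet changed the read-out beyond the scatter.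

Compound 4, `CC#C[C@@H](CC(=O)O)c1ccc(OC[C@H]2COc3ccc(OC(F)(F)F)cc3O2)cc1`, is the next member. The difference from compound 3 is trifluoromethyl in place of methyl on an oxygen on an aromatic ring. For the measured compounds named here, none of the measured steps touches this exact change, since the earlier steps swap whole groups on the aromatic carbon, while here the group is kept and only its methyl is exchanged for trifluoromethyl on the oxygen. Going by the values given here, the steps that bear on it are a 1.6-fold lower number from compound 1 to compound 3 (0.21 log units; within the scatter) and a 1.6-fold lower number from compound 2 to compound 3 (0.21 log units; within the scatter), both small, which show that this corner of the core has tolerated fluoro, bromo and methoxy alike.

On that ground compound 4 is expected to stay within the scatter of compound 3, with an estimated step of a 1.2-fold higher number from compound 3 to compound 4 (0.06 log units; within the scatter). The estimate for compound 4 is 150 nM, within a range from 60 nM to 400 nM.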

Compound 4, half-maximal effective concentration: 700 nM
For compound 4 the middle estimate is 4.7-fold (0.67 log units) below the measured one, and the stated range ends below it.
By their numbers in this assay, from the lowest: compounds 3, 1 and 2 (each within the scatter of the next); then compound 4.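

This place on the shared core now separates compounds in this assay: fluoro, bromo and methoxy had stayed within the scatter of one another, but trifluoromethoxy does not, as the steps show (a 5.4-fold higher number from compound 3 to compound 4 (0.73 log units; beyond the scatter); a 3.3-fold higher number from compound 2 to compound 4 (0.52 log units; beyond the scatter); a 3.3-fold higher number from compound 1 to compound 4 (0.52 log units; beyond the scatter)). The step from methoxy to trifluoromethoxy keeps the oxygen on the aromatic ring and exchanges only methyl for trifluoromethyl, so the read-out here depends on more than the atom attached directly to the ring, and all three steps run towards a higher number. Nothing given here bears on why this exchange moves the read-out.

The compounds shown leave open whether an ethyl or a difluoromethyl on that oxygen would read like compound 3 or like compound 4, and so whether the fluorines or the larger group as a whole go with the higher number. Also open, going by these compounds, is how an amine or a nitrile on the same aromatic carbon would read, and whether the step from methyl to trifluoromethyl would hold on another core.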